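Two Bromophenyl Hydrazones and Their Cell Toxicity

A few compounds are considered here, and "the series" means these few. Any claim that something is new, unique, unknown or untested is made for them only; others in the source may bear on it.

Measured so far:
compound 1 `C/C(=N\NC(=O)COc1cccc2ccccc12)c1ccccc1Br`: 20 ug/mL
compound 2 `CSc1ccc(/C=N/NC(=O)COc2cccc3ccccc23)cc1`: >= 100 ug/mL

Both were tested in an ADME assay on HEL cells (Homo sapiens) for cytotoxicity; on this read-out higher numbers stand for lower toxicity in this test and lower numbers for higher toxicity in this test. For the measured compounds named here, compound 1 gives 20 ug/mL in this assay, and this is the only plain number among the values shown. For compound 2 the result is a limit of the assay rather than a number, namely >= 100 ug/mL. This is the limit of >= 100 ug/mL in this assay, at which 1 of the 2 values shown sits.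

Compound 3 `C/C(=N\NC(=O)COc1cccc2ccccc12)c1ccc(Br)cc1` has not yet been measured in this assay. It differs from compound 1 in one place: 4-bromophenyl in place of 2-bromophenyl on a carbon with a double bond to nitrogen. The two hold the same atoms, joined differently. Going by the values given here, no step between two measured compounds that differ in only one place is available, since compound 1 and compound 2 differ in more than one place, so the expectation for compound 3 rests on compound 1 alone.

A small step of a 2.0-fold higher number from compound 1 to compound 3 (0.30 log units; within the scatter) toward lower toxicity is expected, of a size that may stay within the usual scatter. The estimate for compound 3 in this assay is 40 ug/mL, with a range from 15 ug/mL to 100 ug/mL. The result may also come back only as a limit.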

Compound 3, minimum cytotoxic concentration: 20 ug/mL
The estimate for compound 3 lay 2.0-fold (0.30 log units) above the measured number, within the range that was stated.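

Before this result, compound 1 was the only plain number in the series, so nothing showed whether the place of the bromine on the phenyl ring mattered for toxicity to these cells. With 4-bromophenyl in place of 2-bromophenyl, on a carbon with a double bond to nitrogen, this assay shows no change at the digits printed from compound 1 to compound 3 (within the scatter), so for this pair, whose atoms are the same but joined differently, the read-out does not tell the two arrangements apart. Compound 2 remains the only compound that gives a limit and not a number: the limit of >= 100 ug/mL in this assay, at which 1 of the 3 values shown sits.

The compounds shown leave open whether a different group in place of the bromine, such as an amine or a carboxylic acid, would give a different reading at this spot, since both numbers here come from bromophenyl groups alone. Compound 2 also differs from compound 1 and from compound 3 in more than one place, so its limit cannot be tied to any single part of its structure.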